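Dropping the Methyl Group: From Compound 1 to Compound 3

The source may hold more compounds than are shown below. What is called first, only, known or untested is meant among the compounds shown, and "the series" means these compounds.

Measured compounds:
compound 1 `Cc1ccc(NC2=CC(=O)c3nc4n(c3C2=O)[C@H]2OC[C@@H](O)[C@H]2OC4)cc1`: 1420 nM
compound 2 `CCOc1ccc(NC2=CC(=O)c3c(nc4n3[C@H]3OC[C@@H](O)[C@H]3OC4)C2=O)cc1`: 2090 nM

In a functional assay on MGC-803 cells (Homo sapiens) for inhibition, read by sulforhodamine B assay (on this read-out lower numbers stand for stronger inhibition and higher numbers for weaker inhibition), compound 1 gives 1420 nM. Compound 2 gives 2090 nM, and the two numbers lie within the usual scatter of each other, so neither is distinguished by these data. Compound 3 `O=C1C=C(Nc2ccccc2)C(=O)c2c1nc1n2[C@H]2OC[C@@H](O)[C@H]2OC1` differs from compound 1 by hydrogen in place of methyl on an aromatic carbon. Going by the values given here, no measured pair shows this kind of change, so the step from compound 1 to compound 3 is expected to be small, likely no larger than the scatter, with a slight drift toward weaker inhibition. Compound 3 is estimated at 1800 nM, in a range from 700 nM to 4500 nM.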

Compound 3, half-maximal inhibitory concentration: 1730 nM
Compound 3: the middle estimate sits 1.0-fold (0.02 log units) above what was measured; the range from low to high includes it.
By their numbers in this assay, from the lowest: compounds 1, 3 and 2 (each within the scatter of the next).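

In this assay, replacing 4-methylphenyl with phenyl gives a 1.2-fold higher number from compound 1 to compound 3 (0.09 log units; within the scatter) and this step lies within the scatter. The methyl group on this aromatic carbon is therefore not needed to keep the number in this range, and a bare hydrogen serves there as well. No supporting data bear on this result. The compounds shown leave open whether an amine, a carboxylic acid or a longer chain at this place would move the number beyond the scatter, and in which direction.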